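The compounds below may be only part of what the source reports. "The series", "measured", "known", "first", "only" and "open" are said of these compounds alone.

Compound 1 `CCOC(=O)CO/N=C(/c1ccc(OC)c(OC)c1OC)c1cccc2ccccc12` is the stronger of two measured compounds. In a functional assay on A549 cells (Homo sapiens) for inhibition, read by sulforhodamine B assay, with a stated time of 48 h (on this read-out lower numbers stand for stronger inhibition and higher numbers for weaker inhibition), compound 1 gives 6720 nM, the lowest number among the two. Compound 2 `C=C(c1ccc(OC)c(OC)c1OC)c1cccc2ccccc12` gives 19800 nM in this assay, a higher number than compound 1, and the gap between the two lies beyond the usual scatter of repeated measurements. Compound 3 `COc1ccc(/C(=N/OC(C)=O)c2cccc3ccccc23)c(OC)c1OC` has not yet been measured. It differs from compound 1 in a single place: acetyl in place of (ethoxycarbonyl)methyl on an oxygen. Among the measured compounds shown here, no step of this kind between measured compounds is available, so there is no direct guide to its size. A smaller group of the same general type replaces a larger one at the same oxygen. A step no larger than the scatter is expected, in either direction. The expected step for compound 3 is a 1.2-fold higher number from compound 1 to compound 3 (0.08 log units; within the scatter). Compound 3 is estimated at 8000 nM, with a range from 3000 nM to 25000 nM.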

Compound 3, half-maximal inhibitory concentration: 17200 nM
For compound 3 the middle estimate is 2.2-fold (0.33 log units) below the measured one; low and high end bracket the measured number.
By their numbers in this assay, from the lowest: compound 1; then compounds 3 and 2 (each within the scatter of the next).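

Among the compounds shown here, this is the first measured step at the oxygen bonded to the double-bonded nitrogen: in this assay, acetyl in place of (ethoxycarbonyl)methyl gives a 2.6-fold higher number from compound 1 to compound 3 (0.41 log units; beyond the scatter). The step is modest, but it shows that the group on this oxygen is not a free choice, since exchanging one non-ring group with a carbonyl for another moves the number past the usual scatter, and the larger group goes with the lower number in this pair. No measurement shown here explains why the number moves.

Open, as far as these compounds go, is how the number would respond to other groups on this oxygen, such as a plain methyl, a longer ester chain or a free carboxylic acid. One step also cannot show whether the size of the group or the way it is attached goes with the change.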